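From ethoxy to 3-methylphenyl on the saturated chain carbon

A few compounds are considered here, and "the series" means these few. Any claim that something is new, unique, unknown or untested is made for them only; others in the source may bear on it.

Measured in a functional assay on KB cells (Homo sapiens) for inhibition; on this read-out lower numbers stand for stronger inhibition and higher numbers for weaker inhibition
- compound 1 `C=CCn1c(N)c(C#N)c2c(N)ncnc21` gives > 100000 nM as a limit of the assay
- compound 2 `CCOCn1c(N)c(C#N)c2c(N)ncnc21` gives 138000 nM as a measured number

For the measured compounds named here, compound 2 holds the only actual number so far, so there is no measured value to rank it against. The other reading, (the limit of > 100000 nM in this assay, at which 1 of the 2 values shown sits), is a limit for compound 1 and nothing more.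

Compound 3 `Cc1cccc(Cn2c(N)c(C#N)c3c(N)ncnc32)c1` keeps the shared core and differs from compound 2 as follows: 3-methylphenyl in place of ethoxy on a saturated chain carbon bound to an aromatic nitrogen. Going by the values given here, the only measured step on this chain is a step that the limit leaves unreadable from compound 1 to compound 2 and it offers neither a size nor a direction to carry over. No shift beyond the scatter is therefore firmly expected, and the estimated change is a 1.5-fold lower number from compound 2 to compound 3 (0.19 log units; within the scatter) in this assay with low confidence. For compound 3 the expected value is 90000 nM with an estimated range of 25000 nM to 250000 nM and a real chance of a limit in place of a number.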

Compound 3, half-maximal inhibitory concentration: > 100000 nM
Compound 3 gave a limit, no number; the forecaster's own chance of this, stated with the estimate: 35%; at least 1.1-fold (0.04 log units) between middle value and limit.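

No new step can be read: compound 3 gives only a limit, as does compound 1, so its steps from compound 1 and compound 2 have no readable size. The compounds shown leave open whether any group at this place gives stronger inhibition than compound 2.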